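The source may hold more compounds than are shown below. What is called first, only, known or untested is meant among the compounds shown, and "the series" means these compounds.

Compound 1 `Cc1cn(Cc2ccc(Cl)cc2Cl)c2c(-c3nnc(NS(=O)(=O)c4cc(F)c(F)cc4F)o3)cc(F)cc12`: 21%
Compound 2 `Cc1cn(Cc2ccc(Cl)cc2Cl)c2c(-c3nnc(NS(=O)(=O)c4ccc(Cl)c(Cl)c4)o3)cc(F)cc12`: -2%
Compound 3 `Cc1cn(Cc2ccc3ccccc3c2)c2c(-c3cc(NS(=O)(=O)c4ccc(F)c(F)c4)no3)cc(F)cc12`: 0%

These three compounds were tested in an assay on isolated protein with prostaglandin F2-alpha receptor (Homo sapiens) as the target, read by FLIPR, tested at 1 uM; a lower number here means a weaker effect, a higher number a stronger effect of the compound at the concentration tested. Compound 2 gives -2%, and compound 3 gives 0%, a value within the usual scatter of compound 2. Compound 1 stands higher, giving 21%, and the measured step of a number 23 percentage points lower from compound 1 to compound 2 (beyond the scatter) separates the two beyond the scatter.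

Compound 4 `Cc1cn(Cc2ccc(Cl)cc2Cl)c2c(-c3nnc(NS(=O)(=O)c4ccc(F)c(F)c4)o3)cc(F)cc12` is not yet measured. It differs from compound 2 in one place: 3,4-difluorophenyl in place of 3,4-dichlorophenyl on a sulfonyl sulfur. Among the measured compounds shown here, the one measured step that bears on this exchange is a number 23 percentage points lower from compound 1 to compound 2 (beyond the scatter), where two chlorines arrived on the sulfonyl-bound ring and the number fell. Going back from chlorines to fluorines might therefore recover some of that loss. Against this, compound 3, which carries the same 3,4-difluorophenyl on its sulfonyl sulfur but a different core, gives 0%. A small rise of a number 10 percentage points higher from compound 2 to compound 4 (within the scatter) in this assay is expected, possibly not beyond the scatter. Compound 4 is estimated at 8%, within -8% to 25%.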

Compound 4, a percentage reported as activity, at one concentration (the size of the read-out at that concentration, not a potency): 26%
Estimate against measurement, compound 4: 18 percentage points below; measured number outside the range, above it.
By their numbers in this assay, from the lowest: compounds 2 and 3 (each within the scatter of the next); then compounds 1 and 4 (each within the scatter of the next).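

In this assay, exchanging 3,4-dichlorophenyl for 3,4-difluorophenyl on the sulfonyl sulfur, with the rest of the molecule unchanged, gives a number 28 percentage points higher from compound 2 to compound 4 (beyond the scatter), so the read-out at this position depends on which halogen the ring carries. Hydrogen in place of fluoro on an aromatic carbon gives a number 5 percentage points higher from compound 1 to compound 4 (within the scatter), so the 2,4,5-trifluorophenyl and 3,4-difluorophenyl rings cannot be told apart here, and among the three rings on this core only the 3,4-dichlorophenyl ring stands lower. No measurement shown here accounts for this difference between chlorine and fluorine.

From the compounds shown here alone, all three rings on this core carry halogens, so it remains open how a plain phenyl ring would read at this position. A methoxy group or a carboxylic acid on the ring is equally unresolved.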